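A few compounds are considered here, and "the series" means these few. Any claim that something is new, unique, unknown or untested is made for them only; others in the source may bear on it.

Working notes on the series. Compound 1 `Cc1nnc(SCc2ccccc2)n1N1C(=O)c2ccccc2C1=O`, compound 2 `CCc1nnc(SCc2ccccc2)n1N1C(=O)c2ccccc2C1=O` and compound 3 `C=CCSc1nnc(CCC)n1N1C(=O)c2ccccc2C1=O` share one core and have been run in a functional assay on PC-3M cells (Homo sapiens) for cytotoxicity, read by MTT assay, with a stated time of 48 h; on this read-out higher numbers stand for weaker inhibition and lower numbers for stronger inhibition. Compound 1 reaches only the limit of the assay, > 200000 nM. Compound 2 likewise returns only a limit, > 200000 nM. Compound 3 also stops at a limit, > 200000 nM. All three measured values sit at the limit of > 200000 nM in this assay, at which 3 of the 3 values shown sit, so compound 3 stands nowhere in particular among them: no ordering can be read. For the measured compounds named here, the single step between measured compounds, a step that the two limits leave unreadable from compound 1 to compound 2, has no readable size.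

Compound 4 `CCCc1nnc(SCc2ccccc2)n1N1C(=O)c2ccccc2C1=O` is still to be measured. It differs from compound 3 by phenyl in place of vinyl on a saturated chain carbon bound to a sulfur, or allylsulfanyl to benzylsulfanyl. Going by the values given here, no measured step covers this change. Among the compounds with values here, what is known is that the benzylsulfanyl group is carried by compound 1 and by compound 2, and both stay at the limit, so the new group has not yet been seen to bring any compound into the readable range.

Compound 4 is therefore expected to show a step that the limit leaves unreadable from compound 3 to compound 4, no step beyond the scatter. The estimate for compound 4 is 300000 nM, within 100000 nM to 1000000 nM, and most likely it will again be reported only as a limit.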

Compound 4, half-maximal inhibitory concentration: > 200000 nM
Compound 4: a limit, no number (the forecaster's own chance of this, stated with the estimate: 85%); the middle value is on the limit's open side.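

No step from compound 1, compound 2 or compound 3 to compound 4 can be read, since each of these compounds returns only a limit and not a number: the limit of > 200000 nM in this assay, at which 4 of the 4 values shown sit.

The compounds shown leave open whether any change on the shared core would give a readable value in this assay.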